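Amide substituent swap on a Caco-2 antiproliferative series

A few compounds are considered here, and "the series" means these few. Any claim that something is new, unique, unknown or untested is made for them only; others in the source may bear on it.

Measured compounds:
Compound 1 `CCN(CC)CCNC(=O)c1ccc(C(CC)(CC)c2ccc(OCCC(O)(CC)CC)c(C)c2)n1CC`: 1630 nM
Compound 2 `CCn1c(C(=O)N(CCC#N)CCC#N)ccc1C(CC)(CC)c1ccc(OCCC(O)(CC)CC)c(C)c1`: > 50000 nM
Compound 3 `CCOc1ccc(NC(=O)c2ccc(C(CC)(CC)c3ccc(OCCC(O)(CC)CC)c(C)c3)n2CC)cc1`: > 50000 nM

For the measured compounds named here, in a functional assay on Caco-2 cells (Homo sapiens) for antiproliferative activity, read by MTT assay, with a stated time of 48 h (on this read-out lower numbers stand for stronger inhibition and higher numbers for weaker inhibition), compound 1 gives 1630 nM, the only true number among the three. In this assay compound 2 gives > 50000 nM, which is a limit of the assay and not a number. Compound 3 gives > 50000 nM in this assay, again a limit and not a number. Compound 3 therefore stands at the weak end of what has been measured, sharing the limit of > 50000 nM in this assay, at which 2 of the 3 values shown sit, with compound 2.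

Compound 4 `CCn1c(C(=O)NC(C)CO)ccc1C(CC)(CC)c1ccc(OCCC(O)(CC)CC)c(C)c1` differs from compound 3 in one place: 1-(hydroxymethyl)ethyl in place of 4-ethoxyphenyl on an amide-type nitrogen. The step that bears on this change is an at least 30-fold higher number from compound 1 to compound 3 (1.48 log units; beyond the scatter), which shows that altering the group on the amide-type nitrogen can move the number a long way. The step that the two limits leave unreadable from compound 2 to compound 3 gives no readable size. Because compound 3 sits at a limit, the direction from it can only be toward a lower number or no change, and a modest improvement is expected, an at least 2.5-fold lower number from compound 3 to compound 4 (0.39 log units; beyond the scatter). Compound 4 is estimated at 20000 nM, within 3000 nM to 60000 nM.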

Compound 4, half-maximal inhibitory concentration: > 50000 nM
Compound 4 ended at the assay's limit; the forecaster's own chance of this, stated with the estimate: 45%; middle value at least 2.5-fold (0.39 log units) away from the limit.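

Replacing 4-ethoxyphenyl with 1-(hydroxymethyl)ethyl on the amide-type nitrogen removes the aromatic ring and adds a hydrogen-bond donor, yet compound 4 stays at the limit, as compound 3 did. Against compound 1, which carries 2-(diethylamino)ethyl on that nitrogen, the change is an at least 30-fold higher number from compound 1 to compound 4 (1.48 log units; beyond the scatter), so among these four compounds only compound 1 gives a true number. The steps to compound 4 from compound 2 and from compound 3 join two limits and cannot be read, so those three compounds cannot be ranked, and all that can be said is where they sit: the limit of > 50000 nM in this assay, at which 3 of the 4 values shown sit.

Still open, on these data alone, is whether the amine of 2-(diethylamino)ethyl or the chain that carries it matters more. A 2-aminoethyl group or a longer 3-(diethylamino)propyl chain on the same nitrogen would help to separate the two.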